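The compounds below may be only part of what the source reports. "The series", "measured", "known", "first", "only" and "open" are said of these compounds alone.

Measured compounds:
compound 1, `COc1cc(-c2nnc(SCc3ccccc3F)o2)ccc1O`, 474000 nM
compound 2, `COc1cc(-c2nnc(SCc3ccccc3Cl)o2)ccc1O`, 564000 nM
compound 3, `COc1cccc(CSc2nnc(-c3ccc(O)c(OC)c3)o2)c1`, 389000 nM

All three were read in an ADME assay on cells (Mus musculus, strain BALB/c) for cytotoxicity, read by MTT assay, with a stated time of 24 h; a lower number here means that less compound is tolerated, a higher number that more compound is tolerated. Compound 2 stands highest of the three numbers, but the gaps are small: a 1.2-fold higher number from compound 1 to compound 2 (0.08 log units; within the scatter) and a 1.4-fold lower number from compound 2 to compound 3 (0.16 log units; within the scatter) both lie within the scatter, as does a 1.2-fold lower number from compound 1 to compound 3 (0.09 log units; within the scatter). The three compounds are therefore indistinguishable in this assay.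

Compound 4, `COc1cc(-c2nnc(SCc3ccccc3Cl)o2)ccc1OCc1ccccc1Cl`, differs from compound 2 by 2-chlorobenzyl in place of hydrogen on an oxygen on an aromatic ring; at one bond further out the change reads hydroxy to (2-chlorobenzyl)oxy. Going by the values given here, none of the measured steps touches that oxygen: all of them vary the group on the saturated chain carbon bound to a sulfur, and every one stayed within the scatter. Among the compounds with values here, no step of the present kind has been measured, so the expectation rests only on how narrowly the three numbers cluster. The step is expected to be about a 1.6-fold lower number from compound 2 to compound 4 (0.21 log units; within the scatter), not clearly beyond the scatter in either direction, with a wide range. In this assay compound 4 is estimated at 350000 nM, between 120000 nM and 800000 nM.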

Compound 4, half-maximal cytotoxic concentration: 144000 nM
Compound 4: the middle estimate sits 2.4-fold (0.39 log units) above what was measured; the range from low to high includes it.
By their numbers in this assay, from the lowest: compound 4; then compounds 3, 1 and 2 (each within the scatter of the next).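

Going by these compounds alone, putting 2-chlorobenzyl in place of hydrogen on the oxygen on an aromatic ring is the only change here that moves the number in this assay beyond the scatter (a 3.9-fold lower number from compound 2 to compound 4 (0.59 log units; beyond the scatter)), so less compound is tolerated once the hydroxy becomes (2-chlorobenzyl)oxy. The oxygen therefore responds in this assay, whereas the swaps among compound 1, compound 2 and compound 3 on the saturated chain carbon bound to a sulfur all stayed within the scatter. Nothing at hand bears on why this step has the size it has.

With a single group on that oxygen, the compounds shown cannot separate the loss of the hydroxy hydrogen from the contribution of the 2-chlorobenzyl group itself. From the compounds shown here alone, whether a methyl, an unsubstituted benzyl or a chain ending in a carboxylic acid on the same oxygen would give a similar step remains open.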